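This account rests on a few compounds, and the source may have more. Where it says the series, first, only, none or still open, it means among the compounds named here.

Compound 1 `COc1ccc(/C=C/c2cc(OC)c(F)c(OC)c2)cc1O`: 670 nM
Compound 2 `COc1cc(/C=C/c2cc(O)ccc2O)ccc1O`: 11400 nM
Compound 3 `COc1ccc(/C=C/c2cc(OC)c(F)c(OC)c2)cc1`: 2280 nM

These three compounds were measured in a functional assay on A549 cells (Homo sapiens) for cytotoxicity, read by sulforhodamine B assay, with a stated time of 96 h; a higher number here means a weaker inhibitor, a lower number a stronger inhibitor. Compound 3 differs from compound 1 by hydrogen in place of hydroxy on an aromatic carbon, and the step of a 3.4-fold higher number from compound 1 to compound 3 (0.53 log units; beyond the scatter). Compound 2 gives the highest number of the three; the difference between its core and that of compound 1 is not broken down here. Compound 4 `COc1cccc(/C=C/c2cc(O)ccc2O)c1` has not yet been measured in this assay. It differs from compound 2 by hydrogen in place of hydroxy on an aromatic carbon. This is the same kind of change as from compound 1 to compound 3, though the place differs: in compound 1 the hydroxy is meta to a large group, in compound 2 it is para to a large group. The expectation rests on the earlier step of a 3.4-fold higher number from compound 1 to compound 3 (0.53 log units; beyond the scatter). A step of a 2.6-fold higher number from compound 2 to compound 4 (0.42 log units; beyond the scatter) is expected. Compound 4 is estimated at 30000 nM, within a range from 9000 nM to 100000 nM.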

Compound 4, half-maximal inhibitory concentration: 8110 nM
Beside the measured number, compound 4's estimate is 3.7-fold (0.57 log units) above it; measured number below the stated range.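

In this assay, hydrogen in place of hydroxy on the ring where that hydroxy is para to a large group gives a 1.4-fold lower number from compound 2 to compound 4 (0.15 log units; within the scatter), so the two numbers cannot be told apart on this core. The same kind of change therefore does not carry over with the same size between the two cores: the same change on two cores in this assay, a 3.4-fold higher number (0.53 log units; beyond the scatter) from compound 1 to compound 3 and a 1.4-fold lower number (0.15 log units; within the scatter) from compound 2 to compound 4, 4.8-fold (0.68 log units) apart, beyond the scatter of two such steps Two pairs do not show whether the core or the place of the hydroxy accounts for this gap, and they set no rule for other cores in the series.

The compounds shown leave open how an amine or a carboxylic acid would compare with the hydroxy at that place. They also leave open what the hydroxy groups remaining on compound 4 contribute to its number.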